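Removing the Remaining Chloro Group from Compound 1

A few compounds are considered here, and "the series" means these few. Any claim that something is new, unique, unknown or untested is made for them only; others in the source may bear on it.

Compound 1 `O=c1c(C(=S)Nc2ccccc2)coc2cc(Cl)ccc12` was tested in a functional assay on PC-3 cells (Homo sapiens) for inhibition, read by sulforhodamine B assay, with a stated time of 48 h, tested at 100 uM (on this read-out lower numbers stand for less inhibition of growth and higher numbers for more inhibition of growth at the one concentration tested), where compound 1 gives 55%, the higher of the two numbers recorded so far. For the measured compounds named here, its companion compound 2 `O=c1c(C(=S)Nc2ccccc2)coc2cc(Cl)c(Cl)cc12`, which carries a second chloro group, gives in this assay only 16%; the step of a number 39 percentage points lower from compound 1 to compound 2 (beyond the scatter) is the only measured change on the shared core. Compound 3 `O=c1c(C(=S)Nc2ccccc2)coc2ccccc12` has not yet been tested. It differs from compound 1 by hydrogen in place of chloro on an aromatic carbon. Going by the values given here, the one measured step bears on this change only indirectly, since it runs the other way, adding a chloro group rather than taking one away, and it was large. Taking away the chloro that compound 1 still carries could move the number either way, so no clear direction is expected in this assay. Compound 3 is estimated at 50%, within 20% to 78%, which corresponds to the expected step of a number 5 percentage points lower from compound 1 to compound 3 (within the scatter).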

Compound 3, percent growth inhibition at one concentration: 63%
Estimate against measurement, compound 3: 13 percentage points below; low and high end bracket the measured number.
By their numbers in this assay, from the lowest: compound 2; then compounds 1 and 3 (each within the scatter of the next).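

In this assay, the step of a number 8 percentage points higher from compound 1 to compound 3 (within the scatter) shows that the chloro on this aromatic carbon, meta to a fused ring and para to a fused ring, can give way to hydrogen without a change beyond the scatter. For the compounds shown here, the earlier step, a number 39 percentage points lower from compound 1 to compound 2 (beyond the scatter), showed only what entering a second chloro does, so the present result adds the first reading of losing the chloro that compound 1 carries, and that loss does not repeat the large size of the earlier step. Nothing available explains why the two steps differ in size.

What the compounds shown leave open is how a group other than chloro or hydrogen, such as an amine or a methoxy group, would read on this same carbon. They also leave open whether a carboxylic acid there would keep the number within the scatter of compound 3.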